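From 4-hydroxyphenyl to 3,4-dimethoxyphenyl

The source may hold more compounds than are shown below. What is called first, only, known or untested is meant among the compounds shown, and "the series" means these compounds.

In a functional assay on PC-3 cells (Homo sapiens) for inhibition, read by sulforhodamine B assay (a lower number here means a stronger inhibitor of growth, a higher number a weaker inhibitor of growth), compound 2 `Oc1ccc(-c2ccc(-c3ccc(-c4nc5c(O)cccc5[nH]4)cc3)cc2)cc1` gives 190 nM, the lower of the two numbers measured, while compound 1 `COc1ccc(-c2ccc(-c3ccc(-c4nc5cc(C)ccc5[nH]4)cc3)cc2)cc1OC` gives 2560 nM, a gap beyond the scatter. Compound 3 `COc1ccc(-c2ccc(-c3ccc(-c4nc5c(O)cccc5[nH]4)cc3)cc2)cc1OC` carries 3,4-dimethoxyphenyl in place of 4-hydroxyphenyl on an aromatic carbon, para to a large group (3,4-dimethoxyphenyl in place of 4-hydroxyphenyl on an aromatic carbon). Compound 1 also bears 3,4-dimethoxyphenyl and gives 2560 nM, although its core differs, so weaker growth inhibition is expected in this assay. The expected change is a 3.7-fold higher number from compound 2 to compound 3 (0.57 log units; beyond the scatter), beyond the scatter and towards a higher number. Compound 3 is estimated at 700 nM, with an expected range of 220 nM to 2200 nM.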

Compound 3, concentration for 50% growth inhibition: 1240 nM
Beside the measured number, compound 3's estimate is 1.8-fold (0.25 log units) below it; measured number inside the range.
By their numbers in this assay, from the lowest: compound 2; then compound 3; then compound 1.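

With the core held fixed, a 6.5-fold higher number from compound 2 to compound 3 (0.81 log units; beyond the scatter) in this assay shows that this change on the aromatic carbon alone weakens growth inhibition. The core also matters with 3,4-dimethoxyphenyl in place, as 4-hydroxy-1H-benzimidazol-2-yl for 5-methyl-1H-benzimidazol-2-yl gives a 2.1-fold lower number from compound 1 to compound 3 (0.31 log units; beyond the scatter) in the same direction of stronger inhibition. Nothing measured here explains either step.

Still open, from the compounds shown here alone, is whether the loss follows from replacing the hydroxyl or from adding the second oxygen-bearing group, which 4-methoxyphenyl or 3,4-dihydroxyphenyl at this position could separate. Going by these compounds, how an aminophenyl group would compare also remains unknown.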